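Cytotoxicity notes: dechlorination of the urea aryl in compound 3

The compounds below may be only part of what the source reports. "The series", "measured", "known", "first", "only" and "open" are said of these compounds alone.

Three compounds of this diaryl urea series have been run in an ADME assay on WI-38 cells (Homo sapiens) for cytotoxicity, read by MTT assay, with a stated time of 72 h; on this read-out lower numbers stand for stronger inhibition and higher numbers for weaker inhibition. Compound 1 `Cn1cnnc1-c1cc(Oc2ccc(NC(=O)Nc3cccc(C(F)(F)F)c3)cc2F)ccn1` gives 12600 nM, compound 2 `CN(C)CCn1cnnc1-c1cc(Oc2ccc(NC(=O)Nc3cccc(C(F)(F)F)c3)cc2F)ccn1` gives 11200 nM, and compound 3 `CN(C)CCCn1cnnc1-c1cc(Oc2ccc(NC(=O)Nc3ccc(Cl)c(C(F)(F)F)c3)cc2F)ccn1` gives 7910 nM. Compound 3 stands lowest of the three numbers, but its gaps to compound 2 and to compound 1 are within the scatter, so the three cannot be ordered. Within the data shown here, the one single-point step measured, a 1.1-fold lower number from compound 1 to compound 2 (0.05 log units; within the scatter), concerns the chain on the triazole nitrogen, not the urea aryl.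

Compound 4 `CN(C)CCCn1cnnc1-c1cc(Oc2ccc(NC(=O)Nc3cccc(C(F)(F)F)c3)cc2F)ccn1` differs from compound 3 by hydrogen in place of chloro on an aromatic carbon. Among the measured compounds shown here, no measured step touches this position; the data give no step for removal of chloro. The 3-(trifluoromethyl)phenyl urea of compound 4 is also present in compound 2, which sits at 11200 nM. On this basis the step of a 1.3-fold higher number from compound 3 to compound 4 (0.12 log units; within the scatter) is expected to stay within the scatter, with no direction claimed. Compound 4 is therefore estimated at 10500 nM in this assay, with a range from 5000 nM to 22000 nM.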

Compound 4, half-maximal inhibitory concentration: 11600 nM
The estimate for compound 4 lay 1.1-fold (0.04 log units) below the measured number; measured number inside the range.
By their numbers in this assay, from the lowest: compounds 3, 2, 4 and 1 (each within the scatter of the next).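

In this assay the position para to a large group and ortho to the trifluoromethyl group now has its first measured step: hydrogen in place of chloro stays within the scatter (a 1.5-fold higher number from compound 3 to compound 4 (0.17 log units; within the scatter)). With the 3-(trifluoromethyl)phenyl urea held constant, the chain on the aromatic nitrogen also stays within the scatter, both for (dimethylamino)methyl in place of dimethylamino (a 1.0-fold higher number from compound 2 to compound 4 (0.02 log units; within the scatter)) and for 2-(dimethylamino)ethyl in place of hydrogen (a 1.1-fold lower number from compound 1 to compound 4 (0.04 log units; within the scatter)). No supporting measurement accompanies these steps, so the data offer no account of them.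

On these data alone, whether a fluoro, methoxy or nitrile at this position would give a step beyond the scatter remains open. Also open, as far as these compounds go, are a morpholine at the chain end and whether the chloro step holds on the shorter chains.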